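This account rests on a few compounds, and the source may have more. Where it says the series, first, only, none or still open, it means among the compounds named here.

The measured compounds:
Compound 1 `Cc1ccc(NC(=O)N[C@@H](C)c2ccccc2)cc1`, which gives 100% in an ADME assay on the whole organism with Oryza sativa as the target, tested at 10 uM; on this read-out higher numbers stand for a weaker effect at the one concentration tested and lower numbers for a stronger effect.
Compound 2 `CCCCCCc1ccc(NC(=O)N[C@@H](C)c2ccccc2)cc1`, which gives 99% in this assay.
Compound 3 `C[C@H](NC(=O)Nc1ccc(C(F)(F)F)cc1)c1ccccc1`, which gives 94% in this assay.

Compound 1 holds the highest of the three numbers, but this means little: the step of a number 1 percentage points lower from compound 1 to compound 2 (within the scatter) and the step of a number 6 percentage points lower from compound 1 to compound 3 (within the scatter) both lie within the usual scatter, as does the step of a number 5 percentage points lower from compound 2 to compound 3 (within the scatter). All three compounds therefore sit at the top of the scale and cannot be told apart in this assay.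

Compound 4 `Cc1ccc(NC(=O)N[C@@H](C)c2ccccc2)c(F)c1` differs from compound 1 in one place: fluoro in place of hydrogen on an aromatic carbon. Going by the values given here, no measured step exchanges a hydrogen for a fluoro, so the closest guides are the two steps that alter groups on the same ring of the shared core. The step from compound 1 to compound 3 swaps one aromatic substituent for another and stays within the scatter; the step from compound 1 to compound 2 lengthens a chain on that ring and also stays within the scatter. A single added fluorine is a smaller change than either, and the number is already at the ceiling, so no step beyond the scatter is expected in this assay.

Compound 4 is therefore estimated at 98%, within a range from 90% to 100%. This estimate means an expected step of a number 2 percentage points lower from compound 1 to compound 4 (within the scatter).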

Compound 4, a percentage reported as activity, at one concentration (the size of the read-out at that concentration, not a potency): 100%
Estimate against measurement, compound 4: 2 percentage points below; low and high end bracket the measured number.
By their numbers in this assay, from the lowest: compounds 3, 2, 1 and 4 (each within the scatter of the next).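

Fluoro in place of hydrogen on an aromatic carbon, ortho to a large group and meta to a methyl group, gives no change at the digits printed from compound 1 to compound 4 (within the scatter) in this assay and leaves compound 4 among the other compounds at the top of the scale. Going by these compounds alone, the earlier steps changed only the group at the ring carbon that holds the methyl group in compound 1, so this is the first sign that a second carbon of that ring can take a new substituent without a step beyond the scatter. The compounds shown offer no measurement that accounts for this result, and with all four so near the top of the scale, it shows only that this small exchange produces no detectable effect here.

Going by these compounds, whether a larger group at this same carbon, such as a methoxy group, an amine or a carboxylic acid, would bring the number down remains open. Also open, on these data alone, is whether fluoro would have any effect in a compound with a clearly lower number, since none of the four compounds provides such a starting point.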